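This account rests on a few compounds, and the source may have more. Where it says the series, first, only, none or still open, it means among the compounds named here.

Of the compounds shown here, three have been measured in an assay on CHO cells for displacement of a labelled ligand from muscarinic acetylcholine receptor M5 (Homo sapiens) (a higher number here means a weaker inhibitor, a lower number a stronger inhibitor), and none of them gives a number. Compound 1 `CN(C)C[C@H]1CN(C)C(=O)O1` reaches only the limit of the assay, at > 100000 nM. Compound 2 `C[N+](C)(C)C[C@H]1CNC(=O)O1` likewise gives only the limit, > 100000 nM. Compound 3 `CN1CCC[C@H]1[C@H]1COC(=O)N1` also stops at the limit of the assay, > 100000 nM. For the measured compounds named here, compound 3 therefore stands apart from neither of the other two: all three sit on the same limit (the limit of > 100000 nM in this assay, at which 3 of the 3 values shown sit), and no step between measured compounds can be read from them.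

The next compound, compound 4 `CN1CCC[C@H]1[C@@H]1COC(=O)N1`, differs from compound 3 only in configuration: the two compounds have the same atoms and bonds and differ only in configuration as drawn: 1 of 2 stereo elements differ; a stereocentre at a saturated ring carbon is drawn S in compound 3 and R in compound 4. In words, the two compounds have the same atoms and bonds and differ only in configuration as drawn; a stereocentre at a saturated ring carbon is drawn S in compound 3 and R in compound 4. Going by the values given here, no measured step shows what such an inversion does here, so no direction can be taken from the data. With every value shown sitting at the limit, the expected step from compound 3 to compound 4 is none beyond the scatter, a number no higher from compound 3 to compound 4 (the limit leaves the size open). Compound 4 is thus estimated at 100000 nM, within 30000 nM to 300000 nM, and the expectation is that it too returns only the limit in this assay.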

Compound 4, inhibition constant: > 100000 nM
Compound 4 was reported as a limit (the forecaster's own chance of this, stated with the estimate: 85%); the middle value sits exactly at the limit.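

Compound 4 returns > 100000 nM in this assay, which is a limit of the assay and not a number. Compound 3 also sits at a limit, so no step can be read between compound 3 and compound 4. The compounds shown leave open what inverting that stereocentre does, and whether any compound of this series gives a number in this assay.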